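The compounds below may be only part of what the source reports. "The series", "measured", "known", "first", "only" and "open" are said of these compounds alone.

Compound 1 `CCn1ncc(OCc2nnc(-c3ccccc3)o2)c(Cl)c1=O`, compound 2 `CC(C)(C)n1ncc(OCc2nnc(-c3cc(F)c(Cl)cc3Cl)s2)c(Cl)c1=O` and compound 3 `Cc1nnc(COc2cnn(C(C)(C)C)c(=O)c2Cl)o1` share one core, and the unmeasured compound 4 `CC(C)(C)n1ncc(OCc2nnc(-c3ccc(F)cc3)o2)c(Cl)c1=O` keeps it. In a functional assay on the whole organism for inhibition, with Mythimna separata as the target, with a stated time of 5 days (a lower number here means that less compound is needed, a higher number that more compound is needed for the effect), compound 3 gives only a limit of the assay, > 300 ug/mL. Compound 1 also gives a limit in this assay, > 300 ug/mL. Compound 2 gives a number in this assay, 67.1 ug/mL. Compound 3 thus stands at the limit of > 300 ug/mL in this assay, at which 2 of the 3 values shown sit, and no single value is known for it. The change from compound 3 to compound 4 is 4-fluorophenyl in place of methyl on an aromatic carbon; in words, 4-fluorophenyl in place of methyl on an aromatic carbon. Among the compounds with values here, no measured pair differs only in this place, so the size of this step has not been observed. Within the data shown here, compound 1 also carries a phenyl group and sits at the limit, whereas compound 2 is the one compound with a measured number. The step from compound 3 to compound 4 is expected to be an at least 1.5-fold lower number from compound 3 to compound 4 (0.17 log units; that floor lies within the scatter), toward less compound being needed. The estimate for compound 4 is 200 ug/mL, with a range from 60 ug/mL to 400 ug/mL.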

Compound 4, half-maximal effective concentration: 5.2 ug/mL
Estimate against measurement, compound 4: 38-fold (1.59 log units) above; measured number outside the range, below it.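

In this assay, replacing methyl with 4-fluorophenyl on the aromatic carbon of the five-membered ring gives an at least 57-fold lower number from compound 3 to compound 4 (1.76 log units; beyond the scatter). This shows that the group at this one place can, with the rest of the molecule unchanged, move the read-out beyond the scatter. The step is only a bound and its true size remains unknown, because compound 3 sits at a limit of the assay: the limit of > 300 ug/mL in this assay, at which 2 of the 4 values shown sit.

No pair among the compounds shown separates the fluorine from the phenyl ring itself, so the share of the fluorine in this step stays open. Also open, on these data alone, is how an amine or a longer chain on this same carbon would compare with methyl and 4-fluorophenyl.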